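Trimethoxyphenyl ureas and thioimidate: ring methoxy removal

The source may hold more compounds than are shown below. What is called first, only, known or untested is meant among the compounds shown, and "the series" means these compounds.

Measured compounds:
compound 1 `CCCCCCCC/C=C\CCCCCCC/C(S)=N/c1c(OC)cc(OC)cc1OC` — 900 nM
compound 2 `CCCCCCCC/C=C\CCCCCCCCNC(=O)Nc1c(OC)cc(OC)cc1OC` — 320 nM
compound 3 `CCCCCCCCCCCCCCCCCCNC(=O)Nc1c(OC)cc(OC)cc1OC` — 900 nM

In an assay on microsomes from intestinal mucosa for inhibition of acyl-CoA:cholesterol acyltransferase (Oryctolagus cuniculus) (a lower number here means a stronger inhibitor, a higher number a weaker inhibitor), compound 2 gives the lowest of the three numbers. Compound 1 and compound 3 each sit at the same higher number, and the gap from compound 2 to either of them is beyond the scatter. Among the measured compounds shown here, the one step between compounds differing in a single place is a 2.8-fold higher number from compound 2 to compound 3 (0.45 log units; beyond the scatter), a change on the chain far from the ring. Compound 1 differs from compound 2 in more than one place, so its value says only where it stands, not what any single change does.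

Compound 4 `CCCCCCCC/C=C\CCCCCCCCNC(=O)Nc1ccc(OC)cc1OC` is not yet measured. It differs from compound 2 by hydrogen in place of methoxy on an aromatic carbon. For the measured compounds named here, no measured step touches the aromatic ring or its methoxy groups; all that is known concerns the chain and the linker. The expectation therefore rests on the series as a whole: compound 2 holds the best number, and a change to an untested part of the structure is estimated more likely to cost than to gain, but without a shown precedent the expected step of a 2.2-fold higher number from compound 2 to compound 4 (0.34 log units; beyond the scatter) is kept modest and the range wide. Compound 4 is thus estimated at 700 nM, between 250 nM and 2500 nM in this assay.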

Compound 4, half-maximal inhibitory concentration: 5400 nM
Compound 4: the middle estimate sits 7.7-fold (0.89 log units) below what was measured, outside the stated range (above it).
By their numbers in this assay, from the lowest: compound 2; then compounds 1 and 3 (each within the scatter of the next); then compound 4.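

In this assay, among the compounds shown here, hydrogen in place of methoxy on an aromatic carbon, ortho to a large group and meta to two methoxy groups, gives a 17-fold higher number from compound 2 to compound 4 (1.23 log units; beyond the scatter), a large step and the first measured change on the ring. This ring step is larger than the only chain step available, a 2.8-fold higher number from compound 2 to compound 3 (0.45 log units; beyond the scatter), so among the single changes shown, this methoxy group counts for more in the number than the change on the chain. No data at hand account for the size of this step.

It remains open whether the loss depends on the methoxy group itself or would also follow with another group at this place, such as ethoxy, methyl or chlorine, since hydrogen is the only replacement shown. Also open, as far as these compounds go, are whether removing either of the other two methoxy groups costs as much, and whether the same removal has a step of similar size on the saturated chain of compound 3.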